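The source may report more compounds than this note shows. Statements on the series, on what has been measured and on what is new or still open speak of the compounds shown alone.

Compound 3 `O=C(Nc1cccc(-n2cc(-c3ccncc3)c(-c3cc(O)cc(Cl)c3)n2)c1)Nc1ccc(Cl)c(Cl)c1` gives -84.7% in a functional assay on LOX IMVI cells (Homo sapiens) for inhibition, read by sulforhodamine B assay, with a stated time of 48 h, tested at 10 uM (a lower number here means a stronger effect, a higher number a weaker effect of the compound at the concentration tested), the lowest of the three numbers measured there. Compound 2 `COc1cc(Cl)cc(-c2nn(-c3cccc(NC(=O)c4cccc(C(F)(F)F)c4)c3)cc2-c2ccncc2)c1` is nearest, and in this assay compound 2 gives 51.7%. Furthest is compound 1 `COc1cc(Cl)cc(-c2nn(-c3cccc(NC(=O)c4ccc(Cl)c(Cl)c4)c3)cc2-c2ccncc2)c1`, and in this assay compound 1 gives 72.8%. Compound 4 `COc1cc(Cl)cc(-c2nn(-c3cccc(NC(=O)Nc4ccc(Cl)c(Cl)c4)c3)cc2-c2ccncc2)c1` differs from compound 3 by methyl in place of hydrogen on an oxygen on an aromatic ring. For the measured compounds named here, the only measured step, a number 21.1 percentage points lower from compound 1 to compound 2 (beyond the scatter), alters the group on the carbonyl carbon and so does not bear on a methyl in place of hydrogen on an oxygen. Compounds 1 and 2 carry methoxy and lie far from compound 3. Going by the values given here, they differ from compound 3 in other places too, and no measured step isolates the change at the oxygen. A step of a number 64.7 percentage points higher from compound 3 to compound 4 (beyond the scatter) in this assay is therefore expected, toward the weaker side, with wide uncertainty. Compound 4 is estimated at -20%, with a range from -90% to 55%.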

Compound 4, a percentage reported as activity, at one concentration (the size of the read-out at that concentration, not a potency): 9.24%
For compound 4 the middle estimate is 29.2 percentage points below the measured one; the measured number falls inside the stated range.
By their numbers in this assay, from the lowest: compound 3; then compound 4; then compound 2; then compound 1.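

In this assay the group on this oxygen matters on its own: hydroxy to methoxy, with nothing else changed, gives a number 93.9 percentage points higher from compound 3 to compound 4 (beyond the scatter) and so moves toward the weaker side. With methoxy kept, (3,4-dichlorophenyl)amino on the carbonyl carbon gives a number 42.5 percentage points lower from compound 2 to compound 4 (beyond the scatter) against 3-(trifluoromethyl)phenyl and a number 63.6 percentage points lower from compound 1 to compound 4 (beyond the scatter) against 3,4-dichlorophenyl, so this second place also shifts the number strongly. Nothing shown here explains either change. From the compounds shown here alone, whether ethoxy, a longer chain on this oxygen, would fall nearer to methoxy or hydroxy stays open. So does whether an amine in place of the hydroxy would keep the low number of compound 3.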